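The compounds below may be only part of what the source reports. "The series", "measured", "known", "first", "only" and "open" are said of these compounds alone.

The measured compounds:

Compound 1 `COc1cccc(C2=NNC(c3ccc(Cl)cc3)C2O)c1`: 35.3 nM in a functional assay on HepG2 cells (Homo sapiens) for antiproliferative activity, read by sulforhodamine B assay, with a stated time of 48 h; a lower number here means a stronger inhibitor, a higher number a weaker inhibitor
Compound 2 `COc1cccc(C2=NNC(c3ccc(Br)cc3)C2O)c1`: 43 nM in this assay
Compound 3 `COc1cc(C2=CC(c3ccc(Cl)cc3)NC(=S)N2)cc(OC)c1OC`: 11 nM in this assay

Compound 1 and compound 2 share one core and differ only by bromo in place of chloro on an aromatic carbon; this change gave a 1.2-fold higher number from compound 1 to compound 2 (0.09 log units; within the scatter). Compound 3 has a different core, and the difference between the core of compound 1 and the core of compound 3 is not broken down here. Among the three measured compounds, compound 3 gives the lowest number in this assay, and its gap to compound 1 and to compound 2 lies beyond the scatter.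

Compound 4 `COc1cc(C2=CC(c3ccc(Br)cc3)NC(=S)N2)cc(OC)c1OC` has not yet been measured. Going by the values given here, it differs from compound 3 by bromo in place of chloro on an aromatic carbon, which is the same change as the one made from compound 1 to compound 2, at a place described in the same way. Since that earlier step stayed within the scatter, compound 4 is expected to sit close to compound 3, with an expected step of a 1.2-fold higher number from compound 3 to compound 4 (0.07 log units; within the scatter) in this assay. The estimate for compound 4 is 13 nM, expected to fall between 6 nM and 28 nM.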

Compound 4, half-maximal inhibitory concentration: 9.5 nM
Beside the measured number, compound 4's estimate is 1.4-fold (0.14 log units) above it; the measured number falls inside the stated range.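

In this assay, putting bromo in place of chloro on the core of compound 3 gave a 1.2-fold lower number from compound 3 to compound 4 (0.06 log units; within the scatter), so the 4-chlorophenyl to 4-bromophenyl change again left the number within the scatter. Set beside the earlier step on the other core, the change carries over without a detectable difference between the two cores: the same change on two cores in this assay, a 1.2-fold higher number (0.09 log units; within the scatter) from compound 1 to compound 2 and a 1.2-fold lower number (0.06 log units; within the scatter) from compound 3 to compound 4, 1.4-fold (0.15 log units) apart, within the scatter of two such steps This shows only that the exchange of these two halogens is tolerated alike on these two cores in this one assay; it rests on two pairs of compounds, gives no order between chloro and bromo, and says nothing about a third core or about a change of larger effect.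

The compounds shown leave open what fluoro, a methoxy group, an amine or a carboxylic acid would give at the same place on either core. Going by these compounds alone, they also leave open which part of the core of compound 3 goes with its lower numbers, as no pair here changes one core into the other one place at a time.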